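A few compounds are considered here, and "the series" means these few. Any claim that something is new, unique, unknown or untested is made for them only; others in the source may bear on it.

Working notes on the series. Compound 1 `Cc1ccccc1NC1=C/C(=N/NC(N)=S)C(=O)N=C1Nc1ccccc1C` and compound 2 `Cc1ccc(NC2=C/C(=N/NC(N)=S)C(=O)N=C2Nc2ccc(C)cc2)cc1` hold the same atoms joined differently; the difference between the two cores is not broken down here. In a functional assay on HCT-116 cells (Homo sapiens) for antiproliferative activity, read by MTT assay, with a stated time of 72 h (on this read-out lower numbers stand for stronger inhibition and higher numbers for weaker inhibition), compound 1 gives 1520 nM and compound 2 gives 7040 nM. Compound 3 `Cc1ccccc1NC1=C/C(=N/N=C(\N)SCc2ccccc2)C(=O)N=C1Nc1ccccc1C` carries, on the core of compound 1, (a group of 11 heavy atoms (8 carbon, 2 nitrogen, 1 sulfur; one six-membered aromatic ring of carbon only) in place of a group of 4 heavy atoms (1 carbon, 2 nitrogen, 1 sulfur; no ring), on a double-bonded nitrogen); in this assay compound 3 gives 13800 nM, a step of a 9.1-fold higher number from compound 1 to compound 3 (0.96 log units; beyond the scatter). Compound 4 `Cc1ccc(NC2=C/C(=N/N=C(\N)SCc3ccccc3)C(=O)N=C2Nc2ccc(C)cc2)cc1` is not yet measured; on the core of compound 2 it carries the same change, (a group of 11 heavy atoms (8 carbon, 2 nitrogen, 1 sulfur; one six-membered aromatic ring of carbon only) in place of a group of 4 heavy atoms (1 carbon, 2 nitrogen, 1 sulfur; no ring), on a double-bonded nitrogen), at the same place. Among the measured compounds shown here, for the step from compound 2 to compound 4 in this assay a weakening of about a 6.4-fold higher number from compound 2 to compound 4 (0.81 log units; beyond the scatter) is expected, resting on the only other example of this change, a 9.1-fold higher number from compound 1 to compound 3 (0.96 log units; beyond the scatter). Compound 4 is therefore estimated at 45000 nM, expected between 15000 nM and 150000 nM.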

Compound 4, half-maximal inhibitory concentration: 8270 nM
Beside the measured number, compound 4's estimate is 5.4-fold (0.74 log units) above it, and the stated range ends above it.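

In this assay the change gives a 1.2-fold higher number from compound 2 to compound 4 (0.07 log units; within the scatter). The step does not carry over unchanged from one core to the other: the same change on two cores in this assay, a 9.1-fold higher number (0.96 log units; beyond the scatter) from compound 1 to compound 3 and a 1.2-fold higher number (0.07 log units; within the scatter) from compound 2 to compound 4, 7.7-fold (0.89 log units) apart, beyond the scatter of two such steps. This pair of steps shows that, for these compounds, the size of the step differs with the core, so a step read on one core is a poor guide to the other; it does not show what in the cores sets that difference, nor how the change would behave on a further core. The compounds shown leave open how the step would look on either core if the group on the double-bonded nitrogen held a morpholine or a carboxylic acid in place of its six-membered aromatic ring of carbon only.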